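This account rests on a few compounds, and the source may have more. Where it says the series, first, only, none or still open, it means among the compounds named here.

Measured so far in an ADME assay on L929 cells (Mus musculus) for cytotoxicity, read by resazurin assay, with a stated time of 48 h; on this read-out higher numbers stand for lower toxicity in this test and lower numbers for higher toxicity in this test:
- compound 1 `C#CCn1c2ccc([N+](=O)[O-])cc2c(=O)n1Cc1ccccc1`: 195000 nM
- compound 2 `O=C(O)CCCn1c2ccc([N+](=O)[O-])cc2c(=O)n1Cc1ccccc1`: > 256000 nM (a limit, not a number)

Compound 2 sits at the limit of > 256000 nM in this assay, at which 1 of the 2 values shown sits, so its position is known only as that limit.

The next compound is compound 3 `CCOCCCn1c2ccc([N+](=O)[O-])cc2c(=O)n1Cc1ccccc1`, with ethoxy in place of carboxy on a saturated chain carbon, three bonds along the chain from an aromatic nitrogen.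

Within the data shown here, only one measured step bears on this change: an at least 1.3-fold higher number from compound 1 to compound 2 (0.11 log units; that floor lies within the scatter). It also links a compound without carboxy to one with it, but its floor stays within the scatter. Compound 1 gives 195000 nM and serves as the nearest reference without carboxy. In this assay, the expected step, an at least 1.3-fold lower number from compound 2 to compound 3 (0.12 log units; that floor lies within the scatter), is estimated to stay within the scatter, with a slightly lower number if any. The estimate for compound 3 is 190000 nM, with an expected range of 90000 nM to 300000 nM.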

Compound 3, concentration lethal to 50% of the cells: 170000 nM
Compound 3: middle estimate off by 1.1-fold (0.05 log units), on the high side; low and high end bracket the measured number.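

In this assay, ethoxy in place of carboxy on a saturated chain carbon, three bonds along the chain from an aromatic nitrogen, gives an at least 1.5-fold lower number from compound 2 to compound 3 (0.17 log units; that floor lies within the scatter), so this change shows no size beyond the scatter so far. Compound 2 is held only as a limit, not a number, which leaves this step with a floor and no measured size: the limit of > 256000 nM in this assay, at which 1 of the 3 values shown sits.

The comparison with the ethynyl compound is the firmer reading, as 2-ethoxyethyl in place of ethynyl gives a 1.1-fold lower number from compound 1 to compound 3 (0.06 log units; within the scatter); the added chain with its ether oxygen thus leaves the number within the scatter.

As far as these compounds go, whether carboxy and ethoxy truly differ at this position stays open. Also open, from the compounds shown here alone, is whether an amine at the chain end, or a longer chain, would move the number beyond the scatter in this assay.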